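The source may hold more compounds than are shown below. What is called first, only, known or untested is meant among the compounds shown, and "the series" means these compounds.

Working notes on the series.

Going by the values given here, compound 2 `CN1CCN(CCCCOc2c(OCc3ccccc3)cc(O)c3c(=O)cc(-c4ccccc4)oc23)CC1` has the lower of the two numbers so far in a functional assay on B16 cells (Mus musculus) for cytotoxicity, read by MTT assay, with a stated time of 72 h; a higher number here means a weaker inhibitor, a lower number a stronger inhibitor: compound 2 gives 2370 nM, and compound 1 `CN(C)CCCCOc1c(OCc2ccccc2)cc(O)c2c(=O)cc(-c3ccccc3)oc12` gives 3220 nM, the two lying within the scatter of each other. Among the compounds with values here, the only measured step, a 1.4-fold lower number from compound 1 to compound 2 (0.13 log units; within the scatter), concerns the amine at the far end of the chain and not the group now in question.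

Compound 3 `CN1CCN(CCCCOc2c(OCc3ccco3)cc(O)c3c(=O)cc(-c4ccccc4)oc23)CC1` differs from compound 2 by furan-2-yl in place of phenyl on a saturated chain carbon bound to an oxygen on an aromatic ring. Within the data shown here, no measured step touches that benzyloxy group, so the single step from compound 1 to compound 2 gives no direct guide to the size of this change; it shows only that the series has so far moved within the scatter. With nothing pointing either way, the expectation for this assay is a step of no more than the scatter, in no preferred direction, which is what a 1.0-fold higher number from compound 2 to compound 3 (0.01 log units; within the scatter) is meant to express. Compound 3 is therefore estimated at 2400 nM, with a range from 1000 nM to 5800 nM.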

Compound 3, half-maximal inhibitory concentration: 3530 nM
Compound 3: middle estimate off by 1.5-fold (0.17 log units), on the low side, within the range that was stated.
By their numbers in this assay, from the lowest: compounds 2, 1 and 3 (each within the scatter of the next).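

Going by these compounds alone, this is the first measured change at the benzyloxy group: in this assay, furan-2-yl in place of phenyl on a saturated chain carbon bound to an oxygen on an aromatic ring gives a 1.5-fold higher number from compound 2 to compound 3 (0.17 log units; within the scatter), a step within the scatter. With 4-methylpiperazin-1-yl held on the chain, this assay therefore does not separate the six-membered aromatic ring of carbon only from the five-membered aromatic ring with one hetero atom and one hydrogen-bond acceptor, so this exchange at this position joins the amine exchange in leaving the numbers within the scatter. No available evidence bears on this result.

As far as these compounds go, whether the same exchange also stays within the scatter with dimethylamino in place of 4-methylpiperazin-1-yl remains open, as this single step comes from one amine only. Also open, from the compounds shown here alone, is whether a more different group on this saturated chain carbon, such as a carboxylic acid, a pyridin-3-yl ring or a longer chain ending in phenyl, would give a step beyond the scatter.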